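Indole glycosides: acetyl replaced by pyridinyl enone

The source may report more compounds than this note shows. Statements on the series, on what has been measured and on what is new or still open speak of the compounds shown alone.

Compound 1 `COc1ccc2c(c1)c(/C=N/O)cn2Cc1cn([C@@H]2O[C@H](COC(C)=O)[C@@H](OC(C)=O)[C@H](OC(C)=O)[C@H]2OC(C)=O)nn1` gives 51000 nM in a functional assay on MCF7 cells (Homo sapiens) for cytotoxicity, read by sulforhodamine B assay, with a stated time of 48 h; a higher number here means a weaker inhibitor, a lower number a stronger inhibitor. Compound 2 `CC(=O)OC[C@H]1O[C@@H](n2cc(Cn3cc(C(C)=O)c4ccccc43)nn2)[C@H](OC(C)=O)[C@@H](OC(C)=O)[C@@H]1OC(C)=O` reaches only a limit, > 200000 nM, in this assay. Compound 2 therefore stands at the limit of > 200000 nM in this assay, at which 1 of the 2 values shown sits, with no number of its own in this assay. Compound 3 `CC(=O)OC[C@H]1O[C@@H](n2cc(Cn3cc(/C=C/C(=O)c4cccnc4)c4ccccc43)nn2)[C@H](OC(C)=O)[C@@H](OC(C)=O)[C@@H]1OC(C)=O` carries the change (2-((pyridin-3-yl)carbonyl)ethenyl in place of acetyl on an aromatic carbon), that is 2-((pyridin-3-yl)carbonyl)ethenyl in place of acetyl on an aromatic carbon. Within the data shown here, no measured step covers this change; the expectation is a move toward stronger inhibition, of a size beyond the scatter, an at least 6.6-fold lower number from compound 2 to compound 3 (0.82 log units; beyond the scatter). Compound 3 is estimated at 30000 nM, with a range from 5000 nM to 200000 nM in this assay.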

Compound 3, half-maximal inhibitory concentration: 22300 nM
Beside the measured number, compound 3's estimate is 1.3-fold (0.13 log units) above it; the range from low to high includes it.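

In this assay, among these compounds, 2-((pyridin-3-yl)carbonyl)ethenyl in place of acetyl on an aromatic carbon gives an at least 8.9-fold lower number from compound 2 to compound 3 (0.95 log units; beyond the scatter), the first measured step at this position, which shows that the read-out responds to a change there. Compound 2 holds a limit rather than a number, so the step has a floor but no known size: the limit of > 200000 nM in this assay, at which 1 of the 3 values shown sits.

From the compounds shown here alone, whether the step depends on the pyridine ring or on the ethenyl carbonyl link remains open. A phenyl ketone, or a carboxylic acid on the same carbon, would help separate these parts.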